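The source may report more compounds than this note shows. Statements on the series, on what has been measured and on what is new or still open speak of the compounds shown alone.

Working notes on the series. In a functional assay on KB cells (Homo sapiens) for antiproliferative activity, read by sulforhodamine B assay, with a stated time of 3 days (a higher number here means a weaker inhibitor of growth, a lower number a stronger inhibitor of growth), compound 1 (`O=C(Nc1ccc(C(F)(F)F)cc1)c1cccc(Nc2ncc(F)c(Nc3ccc(F)cc3)n2)c1`) gives > 10000 nM, which is a limit of the assay and not a number. Compound 2 (`CN(C)c1ccc(C(=O)Nc2cccc(Nc3ncc(F)c(Nc4ccc(F)cc4)n3)c2)cc1`) gives > 10000 nM, which is also a limit. Among the measured compounds shown here, the series so far stands at the limit of > 10000 nM in this assay, at which 2 of the 2 values shown sit, so compound 1 has no numeric position and no measured step is available for comparison.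

Compound 3 (`COc1cc(NC(=O)c2cccc(Nc3ncc(F)c(Nc4ccc(F)cc4)n3)c2)cc(OC)c1`) keeps the core of compound 1 and differs only on an amide-type nitrogen: 3,5-dimethoxyphenyl in place of 4-(trifluoromethyl)phenyl on an amide-type nitrogen. The expectation in this assay is for no change beyond the scatter, in either direction. This expectation rests on the limit of compound 1, > 10000 nM. The estimated size of change is a number no higher from compound 1 to compound 3 (the limit leaves the size open). For compound 3 the expected value is 10000 nM, with an estimated range of 3000 nM to 20000 nM.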

Compound 3, concentration for 50% growth inhibition: 15500 nM
Beside the measured number, compound 3's estimate is 1.6-fold (0.19 log units) below it, within the range that was stated.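

No step can be read from compound 1 to compound 3, because compound 1 has only a limit of the assay and no number: the limit of > 10000 nM in this assay, at which 2 of the 3 values shown sit.

The compounds shown leave open how 3,5-dimethoxyphenyl and 4-(trifluoromethyl)phenyl on an amide-type nitrogen compare in growth inhibition.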